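A few compounds are considered here, and "the series" means these few. Any claim that something is new, unique, unknown or untested is made for them only; others in the source may bear on it.

Three compounds share one core and differ only in the group carried on an aromatic nitrogen. Compound 1 `CC(C)c1onc(-c2c(Cl)cccc2Cl)c1COc1ccc(-c2nc3ccc(C(=O)O)cc3n2Cc2ccc(F)cc2)cc1` gives 105 nM in an assay on isolated protein for agonist activity at Bile acid receptor (Homo sapiens), read by TR-FRET; on this read-out higher numbers stand for an effect only at larger amounts of compound and lower numbers for an effect already at smaller amounts. Compound 2 `CC(C)c1onc(-c2c(Cl)cccc2Cl)c1COc1ccc(-c2nc3ccc(C(=O)O)cc3n2C2CC2)cc1` gives 117 nM in this assay. Compound 3 `CCCC(CCC)n1c(-c2ccc(OCc3c(-c4c(Cl)cccc4Cl)noc3C(C)C)cc2)nc2ccc(C(=O)O)cc21` gives 30.3 nM in this assay, and this is the lowest of the three numbers. The steps leading to it both point the same way: a 3.5-fold lower number from compound 1 to compound 3 (0.54 log units; beyond the scatter) and a 3.9-fold lower number from compound 2 to compound 3 (0.59 log units; beyond the scatter), while a 1.1-fold higher number from compound 1 to compound 2 (0.05 log units; within the scatter). Compound 4 `CC(C)Cn1c(-c2ccc(OCc3c(-c4c(Cl)cccc4Cl)noc3C(C)C)cc2)nc2ccc(C(=O)O)cc21` has not yet been measured. Its change from compound 3 is isobutyl in place of 1-propylbutyl on an aromatic nitrogen. Among the measured compounds shown here, no measured step swaps the 1-propylbutyl for another open chain, so the two steps that reached compound 3 are the only guide, and both lay beyond the scatter. A modest step back toward the numbers of compound 1 and compound 2 is therefore expected, and the estimate is a 2.0-fold higher number from compound 3 to compound 4 (0.30 log units; within the scatter). Compound 4 is expected to give about 60 nM in this assay, with a range from 25 nM to 150 nM.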

Compound 4, half-maximal effective concentration: 24.7 nM
Beside the measured number, compound 4's estimate is 2.4-fold (0.39 log units) above it; the whole stated range lies above it.
By their numbers in this assay, from the lowest: compounds 4 and 3 (each within the scatter of the next); then compounds 1 and 2 (each within the scatter of the next).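

In this assay, shortening the open chain on the aromatic nitrogen from 1-propylbutyl to isobutyl gives a 1.2-fold lower number from compound 3 to compound 4 (0.09 log units; within the scatter), so the low number at this position does not depend on the larger of these two chains. The isobutyl group also stands apart from the two groups that carry a ring: replacing cyclopropyl with it gives a 4.7-fold lower number from compound 2 to compound 4 (0.68 log units; beyond the scatter), while isopropyl in place of 4-fluorophenyl on the saturated chain carbon bound to the aromatic nitrogen gives a 4.3-fold lower number from compound 1 to compound 4 (0.63 log units; beyond the scatter). Among these four compounds, the two open chains therefore give lower numbers than the two ring-bearing groups, and no compound goes against this.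

Nothing available here explains that difference. Also open, as far as these compounds go, is how an unbranched butyl chain, or a chain ending in an amine, would behave at this position.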